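Methoxy to tert-butyl on the pendant phenyl, two cores

The source may report more compounds than this note shows. Statements on the series, on what has been measured and on what is new or still open speak of the compounds shown alone.

Measured in an assay on HepG2 cells for agonist activity at nuclear receptor subfamily 1 group I member 3 (Homo sapiens), read by a luciferase reporter, with a stated time of 23 h; a higher number here means that more compound is needed for the effect, a lower number that less compound is needed:
- compound 1, `COc1ccc(CO/N=C/c2c(-c3ccc4ccccc4c3)nc3occn23)cc1`: 4400 nM
- compound 2, `CC(C)(C)c1ccc(CO/N=C/c2c(-c3ccc4ccccc4c3)nc3occn23)cc1`: 7900 nM
- compound 3, `COc1ccc(-c2nc3sccn3c2/C=N/OCc2ccc(Cl)c(Cl)c2)cc1`: 490 nM

Compound 1 and compound 2 share one core and differ only in the change (tert-butyl in place of methoxy on an aromatic carbon). The step of a 1.8-fold higher number from compound 1 to compound 2 (0.25 log units; within the scatter), so in this core the swap leaves the number essentially where it was.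

Compound 3 has a different core; how the two cores differ is not broken down here. Its number is the lowest of the three, and the gaps from compound 3 to compound 1 and to compound 2 both lie beyond the scatter.

Compound 4, `CC(C)(C)c1ccc(-c2nc3sccn3c2/C=N/OCc2ccc(Cl)c(Cl)c2)cc1`, is not yet measured. It stands to compound 3 as compound 2 stands to compound 1: the change is tert-butyl in place of methoxy on an aromatic carbon, and the place is described in the same words for both pairs, so this is the same change made on the second core. Among the compounds with values here, the only measured precedent is the single pair compound 1 to compound 2, on a different core, so the transfer carries uncertainty.

The expected step is a 1.5-fold higher number from compound 3 to compound 4 (0.18 log units; within the scatter), resting on the measured step of a 1.8-fold higher number from compound 1 to compound 2 (0.25 log units; within the scatter) taken as the guide. Compound 4 is therefore expected to give about 750 nM in this assay, estimated between 250 nM and 2200 nM.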

Compound 4, half-maximal effective concentration: 2400 nM
The estimate for compound 4 lay 3.2-fold (0.51 log units) below the measured number; measured number above the stated range.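

In this assay, tert-butyl in place of methoxy on the aromatic carbon of the core of compound 3 gives a step that can be read as real, a 4.9-fold higher number from compound 3 to compound 4 (0.69 log units; beyond the scatter). Set beside the only other example, the change does not carry over from one core to the other at a single size, so a step measured on one core is a poor guide to its size on the other: the same change on two cores in this assay, a 1.8-fold higher number (0.25 log units; within the scatter) from compound 1 to compound 2 and a 4.9-fold higher number (0.69 log units; beyond the scatter) from compound 3 to compound 4, 2.7-fold (0.44 log units) apart, beyond the scatter of two such steps This shows that the step depends on the surrounding structure in this pair of cores, but with only two pairs it does not show which structural difference between the cores is responsible, since those cores differ in more than one place, nor whether the gap would hold for any other swap.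

Still open, going by these compounds, is how the number moves on both cores with other groups at this same place, para to a large group, such as an amine, a carboxylic acid or a longer alkyl chain. Also open is whether compound 3, with its methoxy, marks a real preference on its core or merely one point among groups not shown here.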